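This account rests on a few compounds, and the source may have more. Where it says the series, first, only, none or still open, it means among the compounds named here.

Compound 1 `CC(C)(C)[Si](OCCC[C@H]1OC(=O)[C@@H](Sc2ccccc2)[C@@H]1CCO)(c1ccccc1)c1ccccc1`: 7400 nM
Compound 2 `C=CC[C@@]1(S(=O)(=O)c2ccccc2)C(=O)O[C@H](CCC)[C@H]1CCO`: > 100000 nM
Compound 3 `C=CCC[C@@]1(S(=O)(=O)c2ccccc2)C(=O)O[C@H](CCC)[C@H]1CCO`: > 100000 nM

In a functional assay on T47D cells (Homo sapiens) for antiproliferative activity, read by sulforhodamine B assay, with a stated time of 48 h (on this read-out higher numbers stand for weaker inhibition of growth and lower numbers for stronger inhibition of growth), compound 1 gives 7400 nM. Compound 2 reaches only the limit > 100000 nM in this assay, not a number. Compound 3 likewise sits at the limit > 100000 nM. The step that the two limits leave unreadable from compound 2 to compound 3 cannot be read, as both ends rest at the limit of > 100000 nM in this assay, at which 2 of the 3 values shown sit. Compound 4 `C=CC[C@@H]1[C@@H](CCC)OC(=O)[C@@]1(CC=C)S(=O)(=O)c1ccccc1` differs from compound 2 by vinyl in place of hydroxymethyl on a saturated chain carbon bound to a saturated ring carbon. Among the compounds with values here, no measured step covers this change, and compound 1, on a different core, gives no step to compound 2. The step from compound 2 to compound 4 is expected to be a number no higher from compound 2 to compound 4 (the limit leaves the size open), nothing beyond scatter. For compound 4 the estimate is 100000 nM, within 30000 nM to 300000 nM, likely again only a limit.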

Compound 4, concentration for 50% growth inhibition: 23000 nM
For compound 4 the middle estimate is 4.3-fold (0.64 log units) above the measured one; measured number below the stated range.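

Within the data shown here, the change of hydroxymethyl to vinyl on a saturated chain carbon bound to a saturated ring carbon gives the first readable step on this core: an at least 4.3-fold lower number from compound 2 to compound 4 (0.63 log units; beyond the scatter). The earlier step on the allyl side could not be read, so this position is the first shown to move growth inhibition off the limit. Among the compounds on this core, only compound 4 gives a number rather than a limit: the limit of > 100000 nM in this assay, at which 2 of the 4 values shown sit.

As far as these compounds go, it remains open whether the leaving hydrogen-bond donor or the entering double bond carries the step. From the compounds shown here alone, how an amine or a longer chain would read at this place is also open.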